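The compounds below may be only part of what the source reports. "The series", "measured", "known", "first", "only" and "open" are said of these compounds alone.

Compound 1 `Cc1cc(C)c2c(c1)CN(c1ccc3c(=O)cc(-c4ccccc4)oc3c1)CO2` and compound 2 `O=c1cc(-c2ccccc2)oc2cc(N3COc4c(Br)cc(Br)cc4C3)ccc12` share one core and differ in the groups on its fused two-ring part. In a functional assay on MCF7 cells (Homo sapiens) for inhibition, read by MTT assay, with a stated time of 48 h, tested at 30 ug/mL (a lower number here means less inhibition of growth, a higher number more inhibition of growth at the concentration tested), compound 1 gives 26.8%. In this assay compound 2 gives 11.1%, which leaves compound 1 with the higher of the two numbers, the gap between them lying beyond the scatter. Compound 3 `Cc1cccc2c1OCN(c1ccc3c(=O)cc(-c4ccccc4)oc3c1)C2` is the next step from compound 1. The change is hydrogen in place of methyl on an aromatic carbon of a six-membered aromatic ring of carbon only, part of a fused or bridged system of two rings, meta to a fused ring, meta to a methyl group and para to a fused ring. For the measured compounds named here, no pair of measured compounds shows this single change, so its size is not known from these numbers. Losing one small group in this way is expected to move this assay only little, if at all, with a slight drop more likely than a rise, as the step of a number 4.8 percentage points lower from compound 1 to compound 3 (within the scatter) is expected to show. For compound 3 the estimate is 22%, within a range from 8% to 36%.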

Compound 3, percent growth inhibition at one concentration: 57.8%
Compound 3: the middle estimate sits 35.8 percentage points below what was measured; the whole stated range lies below it.
By their numbers in this assay, from the lowest: compound 2; then compound 1; then compound 3.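

Taking away this one methyl group, the one para to a fused ring and meta to the methyl group that remains, turns out to be no minor edit: in this assay it gives a number 31 percentage points higher from compound 1 to compound 3 (beyond the scatter), a large step. Compounds 1 and 2 differ in more than one place and could not isolate this carbon, whereas this pair shows that, on this core, hydrogen here goes with clearly more inhibition of growth at the concentration tested than methyl does. Nothing available accounts for the size of this step.

On these data alone, what stays open is whether any group at this carbon lowers the number or methyl alone does, which a fluorine atom, a methoxy group or an amine in the same place would help to settle. Also open, as far as these compounds go, is whether the methyl group that remains in compound 3 matters in the same way, a question that compound 3 set against its counterpart with hydrogen at that carbon as well could answer.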